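A few compounds are considered here, and "the series" means these few. Any claim that something is new, unique, unknown or untested is made for them only; others in the source may bear on it.

Among the compounds with values here, in a functional assay on A-375 cells (Homo sapiens) for cytotoxicity, read by MTT assay (on this read-out higher numbers stand for weaker inhibition and lower numbers for stronger inhibition), compound 3 `COc1ccc(/C=C/C(=O)c2ccc(OC)c3c2OC(C)(C)C=C3)cc1OCCO` gives 9600 nM, the only true number among the measured compounds. Compound 1 `COc1ccc(/C=C/C(=O)c2ccc(OC)c3c2OC(C)(C)C=C3)cc1OCC=C(C)C` reads > 10000 nM, which is a limit and not a number. Compound 2 `C=CCOc1cc(/C=C/C(=O)c2ccc(OC)c3c2OC(C)(C)C=C3)ccc1OC` reads > 10000 nM, which is also a limit. Compound 4 `COc1ccc(/C=C/C(=O)c2ccc(OC)c3c2OC(C)(C)C=C3)cc1OC(=O)CCl` carries (chloromethyl)carbonyl in place of the 2-hydroxyethyl of compound 3, on an oxygen on an aromatic ring: (chloromethyl)carbonyl in place of 2-hydroxyethyl on an oxygen on an aromatic ring. Two measured steps changed the group at this place: an at least 1.0-fold lower number from compound 1 to compound 3 (0.01 log units; that floor lies within the scatter), and an at least 1.0-fold lower number from compound 2 to compound 3 (0.01 log units; that floor lies within the scatter). Neither shows a change beyond the scatter, so no step beyond the scatter is expected in this assay. The expected size is a 1.1-fold lower number from compound 3 to compound 4 (0.03 log units; within the scatter). For compound 4 the estimated value is 9000 nM, with an expected range from 3500 nM to 20000 nM.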

Compound 4, half-maximal inhibitory concentration: 450 nM
Estimate against measurement, compound 4: 20-fold (1.30 log units) above; the measured number lies below the stated range.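

In this assay the group on this oxygen on an aromatic ring clearly matters: the earlier chains showed no step beyond the scatter, yet (chloromethyl)carbonyl in place of 2-hydroxyethyl gives a 21-fold lower number from compound 3 to compound 4 (1.33 log units; beyond the scatter) and, in place of the other two chains, gives an at least 22-fold lower number from compound 2 to compound 4 (1.34 log units; beyond the scatter) and also an at least 22-fold lower number from compound 1 to compound 4 (1.34 log units; beyond the scatter) as the result. Those last two steps are only floors, each starting from a limit and not a number: the limit of > 10000 nM in this assay, at which 2 of the 4 values shown sit.

From the compounds shown here alone, whether the chlorine or the carbonyl carries this step stays open. An acetyl group on the same oxygen, which keeps the carbonyl without the chlorine, would separate the two.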